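Methyl in Place of Fluoro: From Compound 2 to Compound 4

The source may hold more compounds than are shown below. What is called first, only, known or untested is meant among the compounds shown, and "the series" means these compounds.

All three measured compounds share one core and differ only in the substituents of the six-membered aromatic ring of carbon only. Compound 1 `O=C(O)CCc1ccc2[nH]c(-c3ccc(Cl)cc3Cl)cc2c1` carries two chloro groups there, and in a functional assay on CHO cells for agonist activity at Free fatty acid receptor 1 (Homo sapiens), read by a luciferase reporter, with a stated time of 24 h (on this read-out lower numbers stand for an effect already at smaller amounts and higher numbers for an effect only at larger amounts of compound), compound 1 gives 20.6 nM. Compound 3 `O=C(O)CCc1ccc2[nH]c(-c3ccc(Cl)cc3F)cc2c1` has fluoro in place of one chloro; in this assay compound 3 gives > 25 nM, which is a limit of the assay and not a number. Among the measured compounds shown here, the only measured step in this assay is an at least 1.2-fold higher number from compound 1 to compound 3 (0.08 log units; that floor lies within the scatter). Compound 2 `O=C(O)CCc1ccc2[nH]c(-c3cccc(Cl)c3F)cc2c1` places the chloro group differently on that ring. In this assay compound 2 gives > 25 nM, again a limit and not a number. Compound 2 thus stands at the limit of > 25 nM in this assay, at which 2 of the 3 values shown sit, so its true value may lie anywhere beyond that boundary.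

Compound 4 `Cc1c(Cl)cccc1-c1cc2cc(CCC(=O)O)ccc2[nH]1` differs from compound 2 by methyl in place of fluoro on an aromatic carbon. For the measured compounds named here, no measured step exchanges fluoro for methyl, and the one measured step, an at least 1.2-fold higher number from compound 1 to compound 3 (0.08 log units; that floor lies within the scatter), concerns fluoro against chloro and sits within the scatter, so it bears on the present change only loosely and gives no firm direction. With compound 2 known only as a limit, the expected step that the limit leaves unreadable from compound 2 to compound 4 is therefore uncertain. Compound 4 is estimated at 40 nM, with a range from 10 nM to 160 nM.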

Compound 4, half-maximal effective concentration: 0.38 nM
Compound 4: middle estimate off by 110-fold (2.02 log units), on the high side; the measured number lies below the stated range.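

Methyl in place of fluoro on this aromatic carbon, ortho to a chloro group and ortho to a large group, gives an at least 65-fold lower number from compound 2 to compound 4 (1.81 log units; beyond the scatter) in this assay. The earlier compounds offered only an at least 1.2-fold higher number from compound 1 to compound 3 (0.08 log units; that floor lies within the scatter), so this is the first step shown to lie beyond the scatter, and it shows that this position responds strongly to an exchange of one heavy atom for one heavy atom, with no hydrogen-bond donor, hydrogen-bond acceptor or net charge entering or leaving. In this assay compound 2 gives > 25 nM, a limit of the assay and not a number, so the step is known only as a floor and its full size stays unknown: the limit of > 25 nM in this assay, at which 2 of the 4 values shown sit.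

The compounds shown leave open whether the low number of compound 4 belongs to methyl specifically or would also appear with an ethyl or a methoxy group on this aromatic carbon. They also leave open whether the effect of methyl depends on the chloro group beside which the place line sets it, since no compound shown carries methyl without that chloro group.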